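Swapping cyclohexyl for furan-3-yl: expected cytotoxicity outcome

The source may hold more compounds than are shown below. What is called first, only, known or untested is meant among the compounds shown, and "the series" means these compounds.

Measured compounds:
Compound 1, `CN(C)c1ccc(C(=O)NC(=S)N2CCc3c(OCCCCCOc4ccc(Cl)cc4)cccc32)cc1`, in an ADME assay on Huh-7 cells (Homo sapiens) for cytotoxicity (on this read-out higher numbers stand for lower toxicity in this test and lower numbers for higher toxicity in this test), gives > 50000 nM, which is a limit of the assay rather than a number.
Compound 2, `CCCC(=O)NC(=S)N1CCc2c(OCCCCCOc3ccc(Cl)cc3)cccc21`, in this assay gives > 50000 nM, again a limit of the assay.
Compound 3, `O=C(NC(=S)N1CCc2c(OCCCCCOc3ccc(Cl)cc3)cccc21)C1CCCCC1`, in this assay gives > 50000 nM, also a limit of the assay.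

Compound 3 thus stands only at a limit, and the two other values shown are limits as well, so none of the three can be placed above or below another. The steps a step that the two limits leave unreadable from compound 1 to compound 2, a step that the two limits leave unreadable from compound 1 to compound 3 and a step that the two limits leave unreadable from compound 2 to compound 3 are each unreadable in size and give no direction. What the three share is the limit of > 50000 nM in this assay, at which 3 of the 3 values shown sit.

Compound 4, `O=C(NC(=S)N1CCc2c(OCCCCCOc3ccc(Cl)cc3)cccc21)c1ccoc1`, differs from compound 3 by furan-3-yl in place of cyclohexyl on a carbonyl carbon. The measured steps offer no readable guide for this change; the only pointer is the limit of > 50000 nM in this assay, at which 3 of the 3 values shown sit, which makes it most likely that compound 4 will also sit at the limit in this assay. Compound 4 is therefore expected to give an estimated 60000 nM, with a range from 25000 nM to 150000 nM. This corresponds to an expected step that the limit leaves unreadable from compound 3 to compound 4, none beyond the scatter.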

Compound 4, half-maximal cytotoxic concentration: 20100 nM
The estimate for compound 4 lay 3.0-fold (0.47 log units) above the measured number; measured number below the stated range.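

In this assay, among these compounds, the group on this carbonyl carbon can clearly shift the read-out, which the earlier compounds could not show, as their steps among one another cannot be read. Furan-3-yl gives an at least 2.4-fold lower number from compound 3 to compound 4 (0.39 log units; beyond the scatter), and the comparisons with the other two groups give an at least 2.4-fold lower number from compound 2 to compound 4 (0.39 log units; beyond the scatter) and an at least 2.4-fold lower number from compound 1 to compound 4 (0.39 log units; beyond the scatter), making compound 4 the only compound shown with a measured number rather than a limit and the most toxic of the four in this test. Even so, a limit remains the most common result among the compounds shown: the limit of > 50000 nM in this assay, at which 3 of the 4 values shown sit.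

From the compounds shown here alone, the true sizes of these steps remain open, as do the exact values of the three compounds at the limit. Going by these compounds, it is also open whether thiophen-3-yl or furan-2-yl in the same place would give a similar number, which would show how much depends on the ring oxygen or its placement.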